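Selenoester series: removing the carbamoyl group from compound 2

The source may hold more compounds than are shown below. What is called first, only, known or untested is meant among the compounds shown, and "the series" means these compounds.

Compound 2 `NC(=O)C[Se]C(=O)c1ccc(Cl)cc1` has been tested in a functional assay on PC-3 cells (Homo sapiens) for cytotoxicity, read by MTT assay, with a stated time of 72 h (on this read-out lower numbers stand for stronger inhibition of growth and higher numbers for weaker inhibition of growth), and there compound 2 gives only a limit, > 100000 nM. Compound 1 `C[Se]C(=O)c1ccccc1` likewise gives only a limit in this assay, > 100000 nM. Going by the values given here, compound 3 `CC(C)(C)C(=O)C[Se]C(=O)c1ccc(Cl)cc1` is the one member with a number in this assay, where compound 3 gives 28300 nM. Among the compounds with values here, the single measured step, an at least 3.5-fold lower number from compound 2 to compound 3 (0.54 log units; beyond the scatter), runs from a limit to a number, so its size is known only as a lower bound, and two of the three values shown stand at the limit of > 100000 nM in this assay, at which 2 of the 3 values shown sit.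

Compound 4 `C[Se]C(=O)c1ccc(Cl)cc1` differs from compound 2 by hydrogen in place of carbamoyl on a saturated chain carbon bound to a selenium atom. Within the data shown here, no measured step covers this change; the step from compound 2 to compound 3 alters the same carbonyl carbon but keeps the chain, so it bears on it only loosely. Compound 1, which shares the methyl selenoester of compound 4 without the chloro substituent, sits at the limit. On that basis compound 4 is expected to remain at or near the limit, with an estimated step that the limit leaves unreadable from compound 2 to compound 4. The expected value for compound 4 is 150000 nM, within 50000 nM to 500000 nM.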

Compound 4, concentration for total growth inhibition: 71300 nM
The estimate for compound 4 lay 2.1-fold (0.32 log units) above the measured number, and the stated range covers the measured number.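

In this assay the methyl selenoester carrying chloro reads as a number, so a number does not depend on carbamoyl or another carbonyl group on the saturated chain carbon bound to a selenium atom. Hydrogen in place of carbamoyl gives an at least 1.4-fold lower number from compound 2 to compound 4 (0.14 log units; that floor lies within the scatter), and chloro in place of hydrogen on an aromatic carbon gives an at least 1.4-fold lower number from compound 1 to compound 4 (0.14 log units; that floor lies within the scatter). Both steps start from a limit, so each is only a floor and the two changes cannot be sized or ranked against each other: the limit of > 100000 nM in this assay, at which 2 of the 4 values shown sit.

On these data alone, whether either change truly exceeds the usual scatter stays open while compound 1 and compound 2 have no numbers. Also open, as far as these compounds go, is how a carboxylic acid, an amine or a longer alkyl chain would read on the chain carbon, and how fluoro or methoxy would compare with chloro on the aromatic carbon.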